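Trading a pyridine for a chlorofluorophenyl group

This account rests on a few compounds, and the source may have more. Where it says the series, first, only, none or still open, it means among the compounds named here.

Of the compounds shown here, three in one series have been measured in an in vitro ADME assay on microsomes from liver (Rattus norvegicus) for metabolic stability; on this read-out lower numbers stand for slow clearance and higher numbers for fast clearance. Compound 1 `CC(C)NC(=O)[C@H]1CC[C@@H](n2/c(=N/C(=O)c3ccc(F)cc3)[nH]c3ccc(CN4CCCCC4)cc32)CC1` gives 451 mL.min-1.g-1 in this assay. Compound 2 `CC(C)NC(=O)[C@H]1CC[C@@H](n2/c(=N/C(=O)c3ccc(C#N)c(F)c3)[nH]c3ccc(CN4CCC(C(C)(C)O)CC4)cc32)CC1` gives 29 mL.min-1.g-1. Compound 3 `CC(C)NC(=O)[C@H]1CC[C@@H](n2/c(=N/C(=O)c3cccnc3)[nH]c3ccc(CN4CCC(C(C)(C)O)CC4)cc32)CC1` is reported only as a limit of the assay, < 14 mL.min-1.g-1, so its exact number is not known; it sits at the limit of < 14 mL.min-1.g-1 in this assay, at which 1 of the 3 values shown sits. The one single-point step among these compounds, an at least 2.0-fold lower number from compound 2 to compound 3 (0.31 log units; beyond the scatter), lies beyond the scatter.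

Compound 4 `CC(C)NC(=O)[C@H]1CC[C@@H](n2/c(=N/C(=O)c3ccc(F)c(Cl)c3)[nH]c3ccc(CN4CCC(C(C)(C)O)CC4)cc32)CC1` has not yet been measured. It differs from compound 3 in one place: 3-chloro-4-fluorophenyl in place of pyridin-3-yl on a carbonyl carbon. This change undoes the kind of replacement seen in the measured step, putting a substituted phenyl ring back where compound 2 also carries one. On that basis the step from compound 3 to compound 4 is expected to be upward, with an at least 3.2-fold higher number from compound 3 to compound 4 (0.50 log units; beyond the scatter), bringing the number back toward the value of compound 2. Compound 4 is therefore estimated at 45 mL.min-1.g-1, within a range from 15 mL.min-1.g-1 to 140 mL.min-1.g-1.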

Compound 4, intrinsic clearance in microsomes: 44 mL.min-1.g-1
Estimate against measurement, compound 4: 1.0-fold (0.01 log units) above, and the stated range covers the measured number.
By their numbers in this assay, from the lowest: compounds 2 and 4 (each within the scatter of the next); then compound 1. At a limit, below all of these: compound 3.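

In this assay, placing a substituted phenyl ring back on the carbonyl carbon gives an at least 3.1-fold higher number from compound 3 to compound 4 (0.49 log units; beyond the scatter), so the gain seen with pyridin-3-yl is lost with a second phenyl ring and not only with the 4-cyano-3-fluorophenyl of compound 2. The two substituted phenyl rings cannot be told apart on this read-out, with a 1.5-fold higher number from compound 2 to compound 4 (0.18 log units; within the scatter). Compound 3 is reported only as a limit of the assay: the limit of < 14 mL.min-1.g-1 in this assay, at which 1 of the 4 values shown sits.

The compounds shown leave open whether an unsubstituted phenyl ring on this carbonyl carbon would read like the substituted rings or like pyridin-3-yl, and whether pyridin-4-yl would behave as pyridin-3-yl does. As far as these compounds go, the true number of compound 3 is also unknown, so the full size of the step to compound 4 stays open.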